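A few compounds are considered here, and "the series" means these few. Any claim that something is new, unique, unknown or untested is made for them only; others in the source may bear on it.

compound 1 `O=C(CCC(=O)OCCCCCCSc1ccc([N+](=O)[O-])c2nonc12)Nc1ccccc1F`: 840 nM
compound 2 `Cc1ccccc1NC(=O)CCC(=O)OCCCCCCSc1ccc([N+](=O)[O-])c2nonc12`: 1410 nM
compound 3 `Cc1ccc(NC(=O)CCC(=O)OCCCCCCSc2ccc([N+](=O)[O-])c3nonc23)cc1`: 2340 nM

In an ADME assay on HUVEC cells (Homo sapiens) for cytotoxicity, read by MTT assay, with a stated time of 72 h (on this read-out lower numbers stand for stronger inhibition and higher numbers for weaker inhibition), compound 2 gives 1410 nM. The two measured steps that touch this value are a 1.7-fold higher number from compound 1 to compound 2 (0.22 log units; within the scatter) and a 1.7-fold higher number from compound 2 to compound 3 (0.22 log units; within the scatter). The only clear separation among the three is a 2.8-fold higher number from compound 1 to compound 3 (0.44 log units; beyond the scatter).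

The next structure is compound 4 `O=C(CCC(=O)OCCCCCCSc1ccc([N+](=O)[O-])c2nonc12)Nc1ccc(C(F)(F)F)cc1`, which carries 4-(trifluoromethyl)phenyl in place of 2-methylphenyl on an amide-type nitrogen. The closest guide is a 1.7-fold higher number from compound 2 to compound 3 (0.22 log units; within the scatter), which brings 4-methylphenyl onto that same nitrogen. Going by the values given here, no measured compound carries trifluoromethyl, so that part of the change remains untested. A small upward move in this assay is therefore expected, probably not beyond the scatter. The estimated change is a 1.4-fold higher number from compound 2 to compound 4 (0.15 log units; within the scatter). For compound 4 the expected value is 2000 nM, with an estimated range of 800 nM to 5000 nM.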

Compound 4, half-maximal inhibitory concentration: 1390 nM
The estimate for compound 4 lay 1.4-fold (0.16 log units) above the measured number; measured number inside the range.
By their numbers in this assay, from the lowest: compounds 1, 4, 2 and 3 (each within the scatter of the next, the first and the last beyond it).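

In this assay, going by these compounds alone, trifluoromethyl appears for the first time, and 4-(trifluoromethyl)phenyl in place of 2-methylphenyl on the amide-type nitrogen gives a 1.0-fold lower number from compound 2 to compound 4 (0.01 log units; within the scatter) with no separation from the earlier value. Trifluoromethyl in place of methyl gives a 1.7-fold lower number from compound 3 to compound 4 (0.23 log units; within the scatter) and 4-(trifluoromethyl)phenyl in place of 2-fluorophenyl gives a 1.7-fold higher number from compound 1 to compound 4 (0.22 log units; within the scatter) and neither step is clear of the scatter, so compound 4 cannot be told apart from any of the other three, even though a 2.8-fold higher number from compound 1 to compound 3 (0.44 log units; beyond the scatter) remains the one clear gap. Nothing measured here speaks to why these steps are so small.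

From the compounds shown here alone, whether a carboxylic acid or an amine in place of trifluoromethyl would move the number beyond the scatter stays open. So does what a plain phenyl on that nitrogen would give.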